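The compounds below may be only part of what the source reports. "The series", "measured", "known", "first", "only" and "open" are said of these compounds alone.

Measured in a functional assay on MCF7 cells (Homo sapiens) for antiproliferative activity, read by MTT assay, with a stated time of 24 h, tested at 50 uM; on this read-out higher numbers stand for a weaker effect at the one concentration tested and lower numbers for a stronger effect:
compound 1 `COc1cccc(C(O)CCn2nc3c(Br)c(Br)c(Br)c(Br)c3n2)c1` gives 22%;
compound 2 `OC(CCn1nc2c(Br)c(Br)c(Br)c(Br)c2n1)c1ccccc1` gives 28%;
compound 3 `C[C@H](O)CCn1nc2c(Br)c(Br)c(Br)c(Br)c2n1` gives 105%.
Compound 4 `CC(O)CCn1nc2c(Br)c(Br)c(Br)c(Br)c2n1` awaits measurement.

On these numbers compound 3 stands highest of the three; its nearest neighbour is compound 2 and its furthest compound 1, both gaps beyond the scatter. Compound 4 differs from compound 3 only in that (the two compounds have the same atoms and bonds; at least one stereo element is drawn with a configuration in one of them and without one in the other: 1 of 1 stereo elements differ; a stereocentre at a saturated chain carbon is drawn S in compound 3 and without a configuration in compound 4). For the measured compounds named here, the one measured step, a number 6 percentage points higher from compound 1 to compound 2 (within the scatter), concerns hydrogen in place of methoxy on an aromatic carbon and does not bear on a stereocentre drawn with or without a configuration; no measured pair shows what that does. Because compound 3 gives 105% with the same atoms and bonds, compound 4 is expected to stay close, a step of a number 7 percentage points lower from compound 3 to compound 4 (within the scatter), within the scatter. Compound 4 is therefore estimated at 98%, between 70% and 115%.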

Compound 4, a percentage reported as activity, at one concentration (the size of the read-out at that concentration, not a potency): 90%
The estimate for compound 4 lay 8 percentage points above the measured number, within the range that was stated.
By their numbers in this assay, from the lowest: compounds 1 and 2 (each within the scatter of the next); then compound 4; then compound 3.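

With atoms and bonds unchanged, this assay shows a number 15 percentage points lower from compound 3 to compound 4 (beyond the scatter), and the only difference behind this modest step is one of drawing: the fact that one of compounds 3 and 4 is drawn with a defined configuration and the other without, at the place where they differ

Replacing the aromatic groups has a far larger effect: methyl in place of phenyl gives a number 62 percentage points higher from compound 2 to compound 4 (beyond the scatter), and methyl in place of 3-methoxyphenyl gives a number 68 percentage points higher from compound 1 to compound 4 (beyond the scatter). The aromatic groups on this saturated chain carbon therefore go with the stronger effect, while methyl goes with a weak one.

The compounds shown leave open how the opposite drawn configuration at this carbon would read, and how an amine or a longer chain in place of the methyl would read.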